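Trifluorophenyl ether in place of a nitrophenyl ether

A few compounds are considered here, and "the series" means these few. Any claim that something is new, unique, unknown or untested is made for them only; others in the source may bear on it.

Compound 3 `CC(C)[C@H](NC(=O)COc1cccc2ccccc12)C(=O)N[C@@H](CC(=O)O)C(=O)COc1ccccc1[N+](=O)[O-]` carries a 2-nitrophenyl group on an oxygen on a saturated carbon. In a functional assay on Jurkat cells (Homo sapiens) (on this read-out higher numbers stand for weaker inhibition and lower numbers for stronger inhibition), compound 3 gives > 100000 nM, which is a limit of the assay and not a number. Compound 1 `CC(C)[C@H](NC(=O)COc1cccc2ccccc12)C(=O)N[C@@H](CC(=O)O)C(=O)COc1ccc2ccccc2c1` gives > 100000 nM in this assay, also a limit. Compound 2 `CC(C)[C@H](NC(=O)COc1cccc2ccccc12)C(=O)N[C@@H](CC(=O)O)C(=O)COc1ccc(Oc2ccccc2)cc1` gives 12700 nM. The step that the two limits leave unreadable from compound 1 to compound 3 is unreadable since both ends sit at the limit of > 100000 nM in this assay, at which 2 of the 3 values shown sit. Compound 4 `CC(C)[C@H](NC(=O)COc1cccc2ccccc12)C(=O)N[C@@H](CC(=O)O)C(=O)COc1cc(F)cc(F)c1F` differs from compound 3 by 2,3,5-trifluorophenyl in place of 2-nitrophenyl on an oxygen on a saturated carbon. Going by the values given here, no measured step covers this change; compound 2 touches a different group, and compound 3 itself rests at a limit. The estimate for compound 4 is weak inhibition around 80000 nM, within 20000 nM to 300000 nM. That estimate means an expected step of an at least 1.2-fold lower number from compound 3 to compound 4 (0.09 log units; that floor lies within the scatter), not placed beyond the scatter.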

Compound 4, half-maximal inhibitory concentration: 30000 nM
The estimate for compound 4 lay 2.7-fold (0.43 log units) above the measured number, and the stated range covers the measured number.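

With 2,3,5-trifluorophenyl on this oxygen, the series gains a second ether that gives a readable number in this assay, as compound 4 gives 30000 nM. Replacing 2-nitrophenyl gives an at least 3.3-fold lower number from compound 3 to compound 4 (0.52 log units; beyond the scatter), and replacing naphthalen-2-yl gives an at least 3.3-fold lower number from compound 1 to compound 4 (0.52 log units; beyond the scatter). Compound 1 and compound 3 each rest at a limit of the assay, so both steps are floors and not full sizes: the limit of > 100000 nM in this assay, at which 2 of the 4 values shown sit.

Which of the three fluorines matter remains open. So does whether a phenyl ring carrying a single fluorine, or a chlorine or a methoxy group, would serve as well.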